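This account rests on a few compounds, and the source may have more. Where it says the series, first, only, none or still open, it means among the compounds named here.

Measured in a functional assay on SEM cells (Homo sapiens) for cytotoxicity, with a stated time of 72 h; a higher number here means that more compound is needed for the effect, a lower number that less compound is needed:
- Compound 1 `C=C[C@@](C)(/C=C/c1ccc(OC)cc1)CCC=C(C)C`: > 36600 nM (a limit)
- Compound 2 `C=C[C@](C)(CCCC(C)C)CCc1ccc(O)cc1`: > 36600 nM (a limit)
- Compound 3 `COc1ccc(/C=C/[C@@](C)(/C=C/c2ccc(O)c(C=O)c2)CCC=C(C)C)cc1`: 4550 nM

Compound 3 is the only one of the three with a true number. Compound 1 and compound 2 are reported only as the limit of > 36600 nM in this assay, at which 2 of the 3 values shown sit, which is a limit and not a number.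

Compound 4 `COc1ccc(/C=C/[C@@](C)(/C=C/c2ccc(O)cc2)CCC=C(C)C)cc1` is not yet measured. It is compound 3 with hydrogen in place of formyl on an aromatic carbon, ortho to a hydroxy group, so 3-formyl-4-hydroxyphenyl becomes 4-hydroxyphenyl: hydrogen in place of formyl on an aromatic carbon.

Within the data shown here, no measured pair isolates this change, so its size in this assay is a judgement. Compound 2 also has no formyl and gives > 36600 nM, a limit, although it differs from compound 4 elsewhere too. A step beyond the scatter towards a higher number, meaning weaker activity, is therefore expected. The estimate is a 4.4-fold higher number from compound 3 to compound 4 (0.64 log units; beyond the scatter). For compound 4 the expected value is 20000 nM, with an estimated range of 8000 nM to 45000 nM.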

Compound 4, half-maximal effective concentration: > 36600 nM
Compound 4: only a limit was reported (the forecaster's own chance of this, stated with the estimate: 50%); middle value at least 1.8-fold (0.26 log units) from the limit.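

Among these compounds, for the first time, a single change can be read in this assay: hydrogen in place of formyl on an aromatic carbon, ortho to a hydroxy group, gives an at least 8.0-fold higher number from compound 3 to compound 4 (0.90 log units; beyond the scatter). With the rest of the molecule unchanged, this one group separates a true number from a limit, so the formyl position matters in this pair. Compound 4 gives > 36600 nM, which is a limit and not a number, so the step has a minimum size but no known full size, and the value joins the others held at that limit: the limit of > 36600 nM in this assay, at which 3 of the 4 values shown sit.

The compounds shown leave open whether formyl itself is required or whether another group on that carbon, such as acetyl, a carboxylic acid or an aminomethyl group, would also give a true number. One pair also cannot show whether the same change would matter as much on a different core.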